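This account rests on a few compounds, and the source may have more. Where it says the series, first, only, none or still open, it means among the compounds named here.

The series shares the core of compound 1 `CN(C)CCn1cnnc1-c1cc(Oc2ccc(NC(=O)N/N=C/c3ccc(Cl)cc3)cc2F)ccn1`, with an aryl group on a carbon with a double bond to nitrogen as the part that changes. In a functional assay on U-87MG ATCC cells (Homo sapiens) for cytotoxicity, read by MTT assay, with a stated time of 72 h (on this read-out higher numbers stand for weaker inhibition and lower numbers for stronger inhibition), compound 1 gives 1370 nM. Compound 2 `CN(C)CCn1cnnc1-c1cc(Oc2ccc(NC(=O)N/N=C/c3cc(Br)c(O)c(Br)c3)cc2F)ccn1` carries a 3,5-dibromo-4-hydroxyphenyl at that carbon. In this assay compound 2 reaches only a limit of the assay, > 100000 nM. Compound 3 `Cc1cc(/C=N/NC(=O)Nc2ccc(Oc3ccnc(-c4nncn4CCN(C)C)c3)c(F)c2)cc(C)c1O` carries a 4-hydroxy-3,5-dimethylphenyl there, and in this assay compound 3 gives 7710 nM. Of the two numbers that are not limits, compound 3 sits highest; the step of a 5.6-fold higher number from compound 1 to compound 3 (0.75 log units; beyond the scatter) separates it from its nearest neighbour, while an at least 12-fold lower number from compound 2 to compound 3 (1.11 log units; beyond the scatter) runs toward it from the limit. Compound 4 `COc1ccc(/C=N/NC(=O)Nc2ccc(Oc3ccnc(-c4nncn4CCN(C)C)c3)c(F)c2)c(OC)c1` differs from compound 3 in one place: 2,4-dimethoxyphenyl in place of 4-hydroxy-3,5-dimethylphenyl on a carbon with a double bond to nitrogen. Both measured steps at this carbon bear on it: an at least 72-fold higher number from compound 1 to compound 2 (1.86 log units; beyond the scatter) and a 5.6-fold higher number from compound 1 to compound 3 (0.75 log units; beyond the scatter) show that the 4-chlorophenyl gave the lowest number and that each hydroxyphenyl group raised it. The 2,4-dimethoxyphenyl has no hydroxyl, but it is not the 4-chlorophenyl either, and the expected step of a 1.5-fold lower number from compound 3 to compound 4 (0.19 log units; within the scatter) is judged modest with the direction uncertain. Compound 4 is therefore estimated at 5000 nM in this assay, with an expected range from 1000 nM to 40000 nM.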

Compound 4, half-maximal inhibitory concentration: 12600 nM
The estimate for compound 4 lay 2.5-fold (0.40 log units) below the measured number, and the stated range covers the measured number.
By their numbers in this assay, from the lowest: compound 1; then compounds 3 and 4 (each within the scatter of the next). At a limit, above all of these: compound 2.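

Compound 4 shows that removing the hydroxyl at this carbon does not by itself restore the low number of the 4-chlorophenyl in this assay: the 2,4-dimethoxyphenyl, with no hydrogen-bond donor, gives a 9.2-fold higher number from compound 1 to compound 4 (0.96 log units; beyond the scatter), while the exchange against the 4-hydroxy-3,5-dimethylphenyl gives a 1.6-fold higher number from compound 3 to compound 4 (0.21 log units; within the scatter), so compounds 3 and 4 cannot be told apart. All three aryl groups that replace the 4-chlorophenyl therefore give higher numbers, with or without a hydroxyl, and no compound shown goes against this. Against the dibromo compound the step is an at least 7.9-fold lower number from compound 2 to compound 4 (0.89 log units; beyond the scatter), yet compound 2 stands at a limit and not at a number: the limit of > 100000 nM in this assay, at which 1 of the 4 values shown sits.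

The compounds shown leave open whether the lower number of compound 1 belongs to the chlorine itself or to the plain 4-substituted pattern of its ring. A 4-methoxyphenyl, a 4-fluorophenyl or an unsubstituted phenyl at this carbon would separate those readings, and a 4-aminophenyl would show how a different donor group compares with the hydroxyphenyl groups.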